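The source may report more compounds than this note shows. Statements on the series, on what has been measured and on what is new or still open speak of the compounds shown alone.

Compound 2 `CN(C(=O)c1c(O)c2cc(Oc3ccccc3)ccc2n(C)c1=O)c1ccccc1` stands lowest of the two numbers in a functional assay on the whole organism for inhibition, with Mus musculus as the target, at a dose of 32 mg/kg by the oral route; a lower number here means less inhibition, a higher number more inhibition at the dose given (going by the name of the read-out): compound 2 gives 26%, whereas compound 1 `CSc1ccc2c(c1)c(O)c(C(=O)N(C)c1ccccc1)c(=O)n2C` gives 100%. Compound 3 `CN(C(=O)c1c(O)c2cc([S+](C)[O-])ccc2n(C)c1=O)c1ccccc1` differs from compound 2 by a group of 3 heavy atoms (1 carbon, 1 oxygen, 1 sulfur; no ring) in place of a group of 7 heavy atoms (6 carbon, 1 oxygen; one six-membered aromatic ring of carbon only), on an aromatic carbon. For the measured compounds named here, the one measured step that bears on this is a number 74 percentage points lower from compound 1 to compound 2 (beyond the scatter), a large loss on entry of phenoxy; compound 3 removes that phenoxy again, and the entering group of 3 heavy atoms is nearer in count to the methylsulfanyl of compound 1 than to phenoxy, so a large rise is expected, though a full return is uncertain. Compound 3 is therefore expected to give 70%, with a range from 35% to 100%. The expected step is a number 44 percentage points higher from compound 2 to compound 3 (beyond the scatter).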

Compound 3, a percentage reported as inhibition, in the whole organism at one dose (the size of the read-out at that dose, not a potency): 100%
Estimate against measurement, compound 3: 30 percentage points below; the range from low to high includes it.
By their numbers in this assay, from the lowest: compound 2; then compounds 1 and 3 (each within the scatter of the next).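

In this assay, the sulfur group with its oxygen on this aromatic carbon undoes the loss seen with phenoxy, giving a number 74 percentage points higher from compound 2 to compound 3 (beyond the scatter). Against methylsulfanyl the same group gives no change at the digits printed from compound 1 to compound 3 (within the scatter), so among these compounds only phenoxy goes with the low number, and at this single dose the two sulfur groups cannot be told apart. Nothing on hand explains either step.

Open, on these data alone, is whether a methoxy, an amine or a carboxylic acid at this place keeps the read-out or loses it as phenoxy does. Also open, as far as these compounds go, is whether compound 1 and compound 3 would separate at a lower dose.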